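Aryl exchange on the ring nitrogen of compound 3

The compounds below may be only part of what the source reports. "The series", "measured", "known", "first", "only" and "open" are said of these compounds alone.

Three amides of the shared core are measured in a functional assay on HT-29 cells (Homo sapiens) for antiproliferative activity, read by MTT assay, with a stated time of 72 h; a higher number here means a weaker inhibitor, a lower number a stronger inhibitor. Compound 1 `CNC(=O)c1cc(Oc2ccc(NC(=O)c3cc4cccnc4n(-c4ccc(F)cc4)c3=O)cc2)ccn1` gives 160 nM. Compound 2 `CCNC(=O)c1cc(Oc2ccc(NC(=O)c3cc4cccnc4n(-c4ccc(F)cc4)c3=O)cc2)ccn1` gives 190 nM. Compound 3 `CCCNC(=O)c1cc(Oc2ccc(NC(=O)c3cc4cccnc4n(-c4ccc(F)cc4)c3=O)cc2)ccn1` gives 84 nM. The steps among them are small: a 1.2-fold higher number from compound 1 to compound 2 (0.07 log units; within the scatter); a 1.9-fold lower number from compound 1 to compound 3 (0.28 log units; within the scatter); a 2.3-fold lower number from compound 2 to compound 3 (0.35 log units; beyond the scatter). Compound 3 thus holds the lowest of the three numbers, its gap to compound 1 within the scatter and only its gap to compound 2 beyond it.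

Compound 4 `CCCNC(=O)c1cc(Oc2ccc(NC(=O)c3cc4cccnc4n(-c4ccc(C(F)(F)F)cc4Cl)c3=O)cc2)ccn1` keeps the propyl amide of compound 3 and changes the aryl on the ring nitrogen: 2-chloro-4-(trifluoromethyl)phenyl in place of 4-fluorophenyl on an aromatic nitrogen. Among the measured compounds shown here, none of the measured steps touches this position; all three concern the chain on the amide nitrogen. For the measured compounds named here, the data therefore give no measured step that bears on this change, and its size and direction in this assay are unknown.

Absent any relevant step, the expected number for compound 4 is taken near that of compound 3, with a wide range: the estimate is 100 nM, between 25 nM and 400 nM. The step this estimate means, a 1.2-fold higher number from compound 3 to compound 4 (0.08 log units; within the scatter), is an expectation only, not a measured change.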

Compound 4, half-maximal inhibitory concentration: 1960 nM
The estimate for compound 4 lay 20-fold (1.29 log units) below the measured number; the whole stated range lies below it.
By their numbers in this assay, from the lowest: compounds 3, 1 and 2 (each within the scatter of the next, the first and the last beyond it); then compound 4.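

Among the compounds shown here, the aryl on the ring nitrogen is the first place where a single exchange gives a large step in this assay: a 23-fold higher number from compound 3 to compound 4 (1.37 log units; beyond the scatter). The largest step printed for the chain on the amide nitrogen is far smaller, a 2.3-fold lower number from compound 2 to compound 3 (0.35 log units; beyond the scatter), so this position, unlike that chain, does not accept the exchange without a clear loss of activity. The entering 2-chloro-4-(trifluoromethyl)phenyl is larger than the leaving 4-fluorophenyl, with 11 heavy atoms against 7 and the same counts of hydrogen-bond donors, acceptors and charge, but no measurement here accounts for the step.

The exchange brings in the chlorine and the trifluoromethyl together, so the step cannot be divided between them without a plain phenyl, or an aryl carrying the chlorine alone or the trifluoromethyl alone, on the ring nitrogen. Going by these compounds, it also stays open whether the same exchange gives a step of this size on the methyl amide of compound 1, or on a longer chain such as butyl on the amide nitrogen.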